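Thioether chain change within a hydrazone series

The source may report more compounds than this note shows. Statements on the series, on what has been measured and on what is new or still open speak of the compounds shown alone.

Measured compounds:
compound 1, `C/C(=N\Nc1nc(SCc2ccccc2)nc2c1nnn2Cc1ccccc1)c1ccccc1O`: 56200 nM
compound 2, `C#CCSc1nc(N/N=C/c2cc(OC)c(OC)c(OC)c2)c2nnn(Cc3ccccc3)c2n1`: 25600 nM

In an ADME assay on GES1 cells (Homo sapiens) for antiproliferative activity, read by MTT assay, with a stated time of 72 h (on this read-out higher numbers stand for weaker inhibition and lower numbers for stronger inhibition), compound 1 gives 56200 nM, while compound 2 gives 25600 nM. Of the two numbers compound 2 stands at the lower one, and its gap to compound 1 lies beyond the usual scatter. For the measured compounds named here, the two compounds differ in more than one place, so no single structural step can be drawn between them.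

Compound 3, `CCCSc1nc(N/N=C/c2cc(OC)c(OC)c(OC)c2)c2nnn(Cc3ccccc3)c2n1`, keeps the whole of compound 2 apart from one change: ethyl in place of ethynyl on a saturated chain carbon bound to a sulfur. Going by the values given here, no measured pair isolates this change, so its effect cannot be read from the series. With the chain kept at the same length and only the triple bond removed, the step in this assay is expected to be small, at most a modest move toward a higher number, and quite possibly none beyond the scatter. Compound 3 is therefore estimated at 32000 nM, with a range from 13000 nM to 75000 nM, which means an expected step of a 1.3-fold higher number from compound 2 to compound 3 (0.10 log units; within the scatter).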

Compound 3, half-maximal inhibitory concentration: > 64000 nM
Compound 3: no number, only a limit (the forecaster's own chance of this, stated with the estimate: 10%); middle value at least 2.0-fold (0.30 log units) from the limit.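

Propyl in place of propargyl on the sulfur gives the first single-place step in the series, and in this assay it reads as an at least 2.5-fold higher number from compound 2 to compound 3 (0.39 log units; beyond the scatter). At this position, on a saturated chain carbon bound to a sulfur, the loss of the triple bond alone therefore moves the read-out beyond the scatter toward weaker inhibition, with the heavy-atom count unchanged. The full size of the step stays unknown, as compound 3 carries only a limit of the assay: the limit of > 64000 nM in this assay, at which 1 of the 3 values shown sits.

On these data alone, what a longer chain, a nitrile or an amine would do at this position remains open. As far as these compounds go, it is also open whether this step would keep its direction and size with a different hydrazone on the shared core.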